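Swapping the Aryl Group on the Triazole of Compound 1

The source may report more compounds than this note shows. Statements on the series, on what has been measured and on what is new or still open speak of the compounds shown alone.

Measured compounds:
- compound 1, `O=C1O[C@H]([C@@H](O)Cn2cc(-c3ccc(Br)cc3)nn2)C(OCc2ccccc2)=C1OCc1ccccc1`: 5620 nM
- compound 2, `O=C1O/C(=C\Cn2cc(-c3cc(F)cc(F)c3)nn2)C(OCc2ccccc2)=C1OCc1ccccc1`: > 100000 nM

Of the compounds shown here, two have been tested in a functional assay on MCF7 cells (Homo sapiens) for antiproliferative activity, read by MTT assay, with a stated time of 72 h; on this read-out higher numbers stand for weaker inhibition and lower numbers for stronger inhibition. Among the compounds with values here, compound 1 gives 5620 nM, the only plain number in this set. Compound 2, a related structure, gives > 100000 nM, which is a limit of the assay rather than a number, as noted in the limit of > 100000 nM in this assay, at which 1 of the 2 values shown sits. So compound 1 stands as the single measured reference point here.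

Compound 3, `O=C1O[C@H]([C@@H](O)Cn2cc(-c3cccc(O)c3)nn2)C(OCc2ccccc2)=C1OCc1ccccc1`, has not yet been tested. It differs from compound 1 in one place: 3-hydroxyphenyl in place of 4-bromophenyl on an aromatic carbon. Within the data shown here, no measured pair shows the effect of such a change, so any expectation is uncertain. Compound 3 is expected to come out modestly weaker than compound 1, with the step of a 2.1-fold higher number from compound 1 to compound 3 (0.33 log units; beyond the scatter). For compound 3 the estimate in this assay is 12000 nM, spanning 3000 nM to 50000 nM.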

Compound 3, half-maximal inhibitory concentration: 51800 nM
For compound 3 the middle estimate is 4.3-fold (0.64 log units) below the measured one; the measured number lies above the stated range.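

In this assay, the group on the aromatic carbon of the five-membered ring clearly affects the result: with the rest of compound 1 unchanged, placing 3-hydroxyphenyl there in place of 4-bromophenyl gives a 9.2-fold higher number from compound 1 to compound 3 (0.96 log units; beyond the scatter). Within the data shown here, this is the first measured step at this position, and it shows that a ring of the same size, with the same heavy-atom count, does not keep the activity. Nothing shown here explains the direction or size of this step.

As far as these compounds go, this single swap removes the bromine, adds the hydroxyl and changes the ring position of the substituent, so the contribution of each remains open. Plain phenyl would provide a simple reference, while an amine or a carboxylic acid on the ring would show how other groups behave here.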